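The compounds below may be only part of what the source reports. "The series", "measured", "known", "first", "only" and "open" are said of these compounds alone.

Of the compounds shown here, two built on the same core have so far been measured in an assay on membranes from lung (Cavia porcellus) for binding affinity to cysteinyl leukotriene receptor (Homo sapiens); on this read-out higher numbers stand for weaker inhibition and lower numbers for stronger inhibition. Compound 1 `CC(Cc1cccc(OCc2ccc3ccccc3n2)c1)CC(C)C(=O)O` gives 24 nM, and compound 2 `CCCC(CCC(=O)O)Cc1cccc(OCc2ccc3ccccc3n2)c1` gives 50 nM. Going by the values given here, compound 2 thus carries the higher of the two numbers, with compound 1 as its only neighbour, the move being a 2.1-fold higher number from compound 1 to compound 2 (0.32 log units; beyond the scatter). Compound 3 `c1cc(CCCCc2nnn[nH]2)cc(OCc2ccc3ccccc3n2)c1` remains unmeasured; it differs from compound 2 by 3-(1H-tetrazol-5-yl)propyl in place of 1-(2-carboxyethyl)butyl on a saturated chain carbon bound to an aromatic carbon. Among the compounds with values here, the one measured step concerns only a rearrangement within the acid-bearing chain and does not cover the exchange of a carboxylic acid for a tetrazole, so it gives no direct guide; its modest size is the sole hint that variation at this position shifts the number little. The expected step is a 1.4-fold higher number from compound 2 to compound 3 (0.15 log units; within the scatter), with wide uncertainty. Compound 3 is accordingly estimated at 70 nM, in a range from 15 nM to 300 nM.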

Compound 3, inhibition constant: 20 nM
Compound 3: middle estimate off by 3.5-fold (0.54 log units), on the high side; measured number inside the range.
By their numbers in this assay, from the lowest: compounds 3 and 1 (each within the scatter of the next); then compound 2.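

Going by these compounds alone, the change from the 1-(2-carboxyethyl)butyl chain to 3-(1H-tetrazol-5-yl)propyl is the first here to replace the carboxylic acid itself, and the position tolerates it, with a 2.5-fold lower number from compound 2 to compound 3 (0.40 log units; beyond the scatter). Against the other acid-bearing chain, 3-carboxy-1-methylbutyl, the same exchange gives a 1.2-fold lower number from compound 1 to compound 3 (0.08 log units; within the scatter), so among these three compounds a carboxylic acid is not required at this position for a number in this range. Nothing available explains the gain over compound 2.

Compound 3 also has an unbranched chain, whereas the chains of compound 1 and compound 2 are both branched, so the loss of the branch and the arrival of the tetrazole cannot be separated. As far as these compounds go, it remains open how an unbranched chain ending in a carboxylic acid, a longer chain ending in the tetrazole, or a chain ending in an amine would compare.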